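The compounds below may be only part of what the source reports. "The series", "measured", "known", "first", "only" and "open" are said of these compounds alone.

Values in an ADME assay for permeability, using PAMPA, at pH 4; on this read-out higher numbers stand for higher permeability and lower numbers for lower permeability:
- compound 1 `CCCCC#Cc1c(C)[nH]c2ccccc2c1=O` (500 10^-6 cm/s)
- compound 2 `CCc1c(C)[nH]c2cc(OC)c(Cl)cc2c1=O` (96.4 10^-6 cm/s)
- compound 3 `CCc1c(C)[nH]c2cc(OC)c(Br)cc2c1=O` (81.9 10^-6 cm/s)

Compound 2 (96.4 10^-6 cm/s) cannot be told apart from compound 3 in this assay, while compound 1 (500 10^-6 cm/s) stands clearly higher than both.

Compound 4 `C=C(CCCCC)c1c(C)[nH]c2cc(OC)c(Cl)cc2c1=O` differs from compound 2 in one place (a group of 7 heavy atoms (7 carbon; no ring) in place of a group of 2 heavy atoms (2 carbon; no ring), on an aromatic carbon): ethyl leaves, and a group with 1 double bond outside aromatic rings enters.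

For the measured compounds named here, the only measured step between compounds differing in one place is a 1.2-fold lower number from compound 2 to compound 3 (0.07 log units; within the scatter). That step is bromo in place of chloro and does not touch the ethyl group, so it sets no size for this change. It does suggest that compound 2 and compound 3 together give a fair baseline.

Going by the values given here, compound 1 is the only measured compound without ethyl, but it differs from compound 2 in more than one place. The value of compound 1 (500 10^-6 cm/s) is therefore only a loose pointer, and the direction of the expected change rests on this single compound.

An upward move of moderate size is expected, with the estimate meaning a 2.3-fold higher number from compound 2 to compound 4 (0.36 log units; beyond the scatter) and with wide uncertainty.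

For compound 4 the estimated value is 220 10^-6 cm/s (expected range 80 10^-6 cm/s to 550 10^-6 cm/s).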

Compound 4, apparent permeability: 768 10^-6 cm/s
Estimate against measurement, compound 4: 3.5-fold (0.54 log units) below; measured number outside the range, above it.
By their numbers in this assay, from the lowest: compounds 3 and 2 (each within the scatter of the next); then compounds 1 and 4 (each within the scatter of the next).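

In this assay, the position on the aromatic carbon two atoms from the ring nitrogen, ortho to a methyl group, proves able to move the read-out: replacing ethyl with the group of 7 heavy atoms, all carbon, with 1 double bond outside aromatic rings gives an 8.0-fold higher number from compound 2 to compound 4 (0.90 log units; beyond the scatter). For the compounds shown here, the only earlier step, a 1.2-fold lower number from compound 2 to compound 3 (0.07 log units; within the scatter), was bromo in place of chloro and left this position untouched, whereas here the change comes with no difference in hydrogen-bond donors, hydrogen-bond acceptors or net charge, since the leaving and entering groups have none. No accompanying data bear on the reason for this step.

This single step does not separate the contribution of the added carbons from that of the double bond, so a saturated hexyl or heptyl chain at the same position would be needed to tell them apart. As far as these compounds go, whether the step survives with an amine or a carboxylic acid at the end of the chain, or with bromo in place of chloro on the shared core, remains open.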